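Swapping Nitrophenyl for Cyanophenyl on a Second Core

The source may hold more compounds than are shown below. What is called first, only, known or untested is meant among the compounds shown, and "the series" means these compounds.

Three compounds have so far been measured in a functional assay on HepG2 cells (Homo sapiens) for cytotoxicity, read by MTT assay, with a stated time of 24 h; on this read-out lower numbers stand for stronger inhibition and higher numbers for weaker inhibition:

compound 1 `O=C1/C(=C/c2cccc([N+](=O)[O-])c2)CN(S(=O)(=O)c2ccc(F)cc2)C/C1=C\c1ccccc1F` gives 7040 nM
compound 2 `N#Cc1ccc(/C=C2\CN(S(=O)(=O)c3ccc(F)cc3)C/C(=C\c3ccccc3F)C2=O)cc1` gives 8180 nM
compound 3 `COc1cc(/C=C2\CN(S(=O)(=O)c3ccc(NC(C)=O)cc3)C/C(=C\c3cccc([N+](=O)[O-])c3)C2=O)cc(OC)c1OC` gives 3340 nM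

Compound 1 and compound 2 share one core and differ by a single change: 4-cyanophenyl in place of 3-nitrophenyl on a double-bonded chain carbon bound to a double-bonded ring carbon. In this assay this gave a 1.2-fold higher number from compound 1 to compound 2 (0.07 log units; within the scatter), so the two cannot be told apart on this read-out. Compound 3 is built on a different core; the difference between the core of compound 1 and the core of compound 3 is not broken down here. Among the three measured compounds, compound 3 has the lowest number, and its gaps to compound 1 and to compound 2 lie beyond the scatter.

Compound 4 `COc1cc(/C=C2\CN(S(=O)(=O)c3ccc(NC(C)=O)cc3)C/C(=C\c3ccc(C#N)cc3)C2=O)cc(OC)c1OC` has not yet been measured. It differs from compound 3 by 4-cyanophenyl in place of 3-nitrophenyl on a double-bonded chain carbon bound to a double-bonded ring carbon, the same change seen from compound 1 to compound 2. The expected step in this assay is a 1.2-fold higher number from compound 3 to compound 4 (0.07 log units; within the scatter), about the size of the earlier one, and it is expected to stay small because a 1.2-fold higher number from compound 1 to compound 2 (0.07 log units; within the scatter) was within the scatter. The estimate for compound 4 in this assay is therefore 3900 nM, expected to fall between 2000 nM and 7600 nM.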

Compound 4, half-maximal inhibitory concentration: 2890 nM
Compound 4: middle estimate off by 1.3-fold (0.13 log units), on the high side, and the stated range covers the measured number.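

In this assay, putting 4-cyanophenyl in place of 3-nitrophenyl on the second core gave a 1.2-fold lower number from compound 3 to compound 4 (0.06 log units; within the scatter), so these two compounds cannot be told apart on this read-out. The change therefore carries over from one core to the other as a step too small to read, and the two steps agree with each other: the same change on two cores in this assay, a 1.2-fold higher number (0.07 log units; within the scatter) from compound 1 to compound 2 and a 1.2-fold lower number (0.06 log units; within the scatter) from compound 3 to compound 4, 1.3-fold (0.13 log units) apart, within the scatter of two such steps. Going by these compounds alone, this shows only that the swap made no readable difference on these two cores; it does not show that the same would hold on a further core, and it gives no reason for the result.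

The compounds shown leave open whether a different group in this place, such as an amine or a carboxylic acid on the aromatic ring, would produce a step beyond the scatter. They also leave open whether the swap would stay as small on any read-out other than this assay.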